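Fluoro to trifluoromethyl on the fused aromatic carbon

The source may hold more compounds than are shown below. What is called first, only, known or untested is meant among the compounds shown, and "the series" means these compounds.

Of the compounds shown here, two carry numbers so far. Compound 1 `CCOc1cc2nn(Cc3nn(CC(=O)O)c(=O)c4ccccc34)cc2cc1Cl` gives 113 nM in a functional assay on CHO cells for antagonist activity at sphingosine 1-phosphate receptor 2 (Homo sapiens), read by GTPgammaS binding; a lower number here means a stronger inhibitor, a higher number a weaker inhibitor. Compound 2 `O=C(O)Cn1nc(Cc2nc3cc(F)c(OCC4CC4)cc3[nH]2)c2ccccc2c1=O` gives 180 nM in this assay; this is the higher of the two numbers, but its gap to compound 1 lies within the scatter, so the two cannot be ordered.

Compound 3 `O=C(O)Cn1nc(Cc2nc3cc(C(F)(F)F)c(OCC4CC4)cc3[nH]2)c2ccccc2c1=O` is the next compound and has not been measured. It differs from compound 2 in one place: trifluoromethyl in place of fluoro on an aromatic carbon, with the cyclopropylmethoxy group kept. For the measured compounds named here, no step between measured compounds of this kind is available, so the expected size rests only on the two numbers above and on the single-site nature of the change. Expected is a small step, a 1.2-fold lower number from compound 2 to compound 3 (0.08 log units; within the scatter), with no firm direction and possibly none beyond the scatter. For compound 3 the estimated value in this assay is 150 nM, within a range of 50 nM to 450 nM.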

Compound 3, half-maximal inhibitory concentration: 67 nM
The estimate for compound 3 lay 2.2-fold (0.35 log units) above the measured number; the range from low to high includes it.
By their numbers in this assay, from the lowest: compounds 3, 1 and 2 (each within the scatter of the next, the first and the last beyond it).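

For the compounds shown here, on this aromatic carbon, ortho to the cyclopropylmethoxy group, trifluoromethyl in place of fluoro gives a 2.7-fold lower number from compound 2 to compound 3 (0.43 log units; beyond the scatter) in this assay, the first single-place step. The number at this carbon therefore responds to the group placed there, and a substituent of four heavy atoms in place of one is tolerated with no loss in this read-out. Nothing measured here bears on the reason for this step.

Going by these compounds, whether the lower number follows the count of fluorine atoms remains open, as does the outcome with methyl or nitrile on this carbon. Also open, on these data alone, is whether the step holds when a longer alkoxy chain replaces the cyclopropylmethoxy group.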